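The source may report more compounds than this note shows. Statements on the series, on what has been measured and on what is new or still open speak of the compounds shown alone.

Compound 1, `N=C(N)Nc1cccc(C(=O)NNC(=O)CC(CC(=O)O)c2ccc(Br)cc2)c1`, gives 1.95 in a physicochemical assay for lipophilicity; a higher number here means a more lipophilic compound, a lower number a more polar compound. For the measured compounds named here, compound 2, `COc1ccc(C(CC(=O)O)CC(=O)NNC(=O)c2cccc(NC(=N)N)c2)cc1`, carries methoxy in place of bromo on an aromatic carbon and gives 1 in this assay, so the step of a number 0.95 log units lower from compound 1 to compound 2 (beyond the scatter) is the only measured step of this kind. Compound 3, `O=C(O)CC(NC(=O)NNC(=O)CCCCNc1ccccn1)c1ccc(Br)cc1`, gives 2.47 and stands highest of the three; the difference between its core and the core of compound 1 is not broken down here. Compound 4, `COc1ccc(C(CC(=O)O)NC(=O)NNC(=O)CCCCNc2ccccn2)cc1`, has not yet been measured and differs from compound 3 by methoxy in place of bromo on an aromatic carbon, the same change as from compound 1 to compound 2. Going by the values given here, from compound 3 to compound 4 a step of a number 0.95 log units lower from compound 3 to compound 4 (beyond the scatter) is expected, resting on the single earlier step of a number 0.95 log units lower from compound 1 to compound 2 (beyond the scatter). Compound 4 is therefore estimated at 1.52, between 1.1 and 1.95.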

Compound 4, partition coefficient: 1.52
The estimate for compound 4 equals the measured number at the digits printed, and the stated range covers the measured number.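

In this assay the change from 4-bromophenyl to 4-methoxyphenyl gives a number 0.95 log units lower from compound 3 to compound 4 (beyond the scatter) and, on the other core, a number 0.95 log units lower from compound 1 to compound 2 (beyond the scatter) in a step of the same size, so the change carried over between these two cores at the digits printed. For the compounds shown here, this rests on only two pairs with the same two groups, and it does not show that the step would hold on any other core. Nothing shown explains why the two steps match.

On these data alone, it remains open whether an amine or a trifluoromethyl group in place of bromo would give matching steps on these two cores. As far as these compounds go, it is also open whether the bromo to methoxy step would hold with a longer chain on the core of compound 3.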